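A few compounds are considered here, and "the series" means these few. Any claim that something is new, unique, unknown or untested is made for them only; others in the source may bear on it.

Measured so far:
Compound 1 `CC(=O)Nc1ccc(S(=O)(=O)Oc2ccccc2C(C)C)cc1` gives in a functional assay on HT-29 cells (Homo sapiens) for antiproliferative activity, read by sulforhodamine B assay, with a stated time of 48 h (on this read-out higher numbers stand for weaker inhibition and lower numbers for stronger inhibition), 23000 nM.
Compound 2 `CC(C)C(=O)Nc1ccc(S(=O)(=O)Oc2ccccc2C(C)C)cc1` gives in this assay 14000 nM.
Compound 3 `CC(C)c1ccccc1OS(=O)(=O)c1ccc(NC(=O)CCl)cc1` gives in this assay 5600 nM.

Compound 3 holds the lowest number of the three; the nearest is compound 2, the furthest compound 1, and both gaps are beyond the scatter. Compound 4 `CC(C)c1ccccc1OS(=O)(=O)c1ccc(NC(=O)CCCl)cc1` differs from compound 3 in one place: chloromethyl in place of chloro on a saturated chain carbon bound to a carbonyl carbon. For the measured compounds named here, two measured steps bear on this change. The step of a 4.1-fold lower number from compound 1 to compound 3 (0.61 log units; beyond the scatter) shows what the chlorine on that chain carbon is worth within this series, and the step of a 2.5-fold lower number from compound 2 to compound 3 (0.40 log units; beyond the scatter) shows what the chloromethyl gives against a branched group on the carbonyl carbon. Compound 4 keeps the chlorine but sets it one carbon further out, so it shares only part of what compound 3 has. The expectation is therefore a rise in the number, of modest size, back toward compound 2 and compound 1, amounting to a 1.8-fold higher number from compound 3 to compound 4 (0.25 log units; within the scatter). For compound 4 the estimate in this assay is 10000 nM, within a range from 4000 nM to 25000 nM.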

Compound 4, half-maximal inhibitory concentration: 16000 nM
The estimate for compound 4 lay 1.6-fold (0.20 log units) below the measured number; low and high end bracket the measured number.
By their numbers in this assay, from the lowest: compound 3; then compounds 2, 4 and 1 (each within the scatter of the next).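

In this assay, the 2-chloroethyl group in place of chloromethyl on the carbonyl carbon gives a 2.9-fold higher number from compound 3 to compound 4 (0.46 log units; beyond the scatter), so the chlorine alone does not carry the advantage of compound 3; its placement on the chain matters. The chlorine-bearing compound 4 does not stand apart from the compounds without chlorine, with a 1.1-fold higher number from compound 2 to compound 4 (0.06 log units; within the scatter) and a 1.4-fold lower number from compound 1 to compound 4 (0.16 log units; within the scatter), leaving compound 3 as the only one of the four with a number beyond the scatter of all the others. Nothing available gives a cause for this difference.

Going by these compounds, what a bromo group or an amine would give on the saturated chain carbon bound to the carbonyl carbon stays open. So does the effect of a longer chain ending in chlorine.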